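The source may report more compounds than this note shows. Statements on the series, on what has been measured and on what is new or still open speak of the compounds shown alone.

In an ADME assay on MCF7 cells (Homo sapiens) for cytotoxicity, with a stated time of 72 h (on this read-out higher numbers stand for weaker inhibition and lower numbers for stronger inhibition), the measured compounds are:

- Compound 1 `COc1cccc(CNc2ncnc3c2ncn3C2CCCCO2)c1`: 97000 nM
- Compound 2 `Oc1ccccc1CNc1ncnc2c1ncn2C1CCCO1`: > 100000 nM (a limit)
- Compound 3 `COc1ccccc1CNc1ncnc2c1ncn2C1CCCO1`: > 100000 nM (a limit)

Compound 3 gives no number, only a limit, and this is the limit of > 100000 nM in this assay, at which 2 of the 3 values shown sit. Compound 4 `COc1cccc(CNc2ncnc3c2ncn3C2CCCO2)c1` has the same atoms as compound 3, joined differently: 3-methoxyphenyl in place of 2-methoxyphenyl on a saturated chain carbon bound to a nitrogen on an aromatic ring. Among the compounds with values here, the only measured step, a step that the two limits leave unreadable from compound 2 to compound 3, offers no size to go on. Compound 1 also carries 3-methoxyphenyl, though it differs elsewhere, and it gives 97000 nM. Little change is therefore expected in this assay, and no direction can be assigned. The expected result is a number no higher from compound 3 to compound 4 (the limit leaves the size open). For compound 4 the estimate is 100000 nM, with an expected range of 50000 nM to 200000 nM.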

Compound 4, half-maximal inhibitory concentration: > 100000 nM
Compound 4 ended at the assay's limit; the forecaster's own chance of this, stated with the estimate: 60%; the middle value lies on the limit itself.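

In this assay compound 4 gives only a limit, so 3-methoxyphenyl in place of 2-methoxyphenyl brings no number clear of it, and the steps linking compound 2, compound 3 and compound 4 cannot be read. Within the data shown here, the one readable step, oxolan-2-yl in place of oxan-2-yl on an aromatic nitrogen, is an at least 1.0-fold higher number from compound 1 to compound 4 (0.01 log units; that floor lies within the scatter). Most of the series now rests at the same ceiling: the limit of > 100000 nM in this assay, at which 3 of the 4 values shown sit.

As far as these compounds go, whether 2-methoxyphenyl and 3-methoxyphenyl differ at all stays open. So does whether an amine or a carboxylic acid on that phenyl ring would give a value clear of the limit.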